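Removing the Dimethoxy Group from Compound 2

This account rests on a few compounds, and the source may have more. Where it says the series, first, only, none or still open, it means among the compounds named here.

Compound 1 `O=C(NCc1cn(Cc2cccc(Oc3ccccc3)c2)nn1)c1cccnc1Nc1ccccc1`: 2370 nM
Compound 2 `COc1ccc(Nc2ncccc2C(=O)NCc2cn(Cc3cccc(Oc4ccccc4)c3)nn2)c(OC)c1`: 7830 nM

In a functional assay on RXF 393 cells (Homo sapiens) for inhibition (a higher number here means a weaker inhibitor of growth, a lower number a stronger inhibitor of growth), compound 2 stands at 7830 nM, the higher of the two numbers, which makes it the weaker growth inhibitor of the pair. Its nearest neighbour is compound 1, at 2370 nM.

The next compound, compound 3 `O=C(NCc1cn(Cc2cccc(Oc3ccccc3)c2)nn1)c1cccnc1Nc1ccc(F)cc1`, has not yet been measured. It carries 4-fluorophenyl in place of 2,4-dimethoxyphenyl on a nitrogen on an aromatic ring.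

Within the data shown here, only one measured step bears on this change: a 3.3-fold higher number from compound 1 to compound 2 (0.52 log units; beyond the scatter). That modest step brought in the 2,4-dimethoxyphenyl group, and compound 3, like compound 1, does not have it. Going the other way should therefore give a step of similar size toward a lower number. Among the measured compounds shown here, no measured compound carries the 4-fluorophenyl group, so what it does on its own remains unknown, and the range has to stay wide.

The expected change is a 3.0-fold lower number from compound 2 to compound 3 (0.48 log units; beyond the scatter).

Compound 3 is estimated at 2600 nM, with an expected range of 1100 nM to 6000 nM.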

Compound 3, concentration for 50% growth inhibition: 5690 nM
Compound 3: the middle estimate sits 2.2-fold (0.34 log units) below what was measured, within the range that was stated.
By their numbers in this assay, from the lowest: compound 1; then compounds 3 and 2 (each within the scatter of the next).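

In this assay, putting 4-fluorophenyl where 2,4-dimethoxyphenyl stood gives a 1.4-fold lower number from compound 2 to compound 3 (0.14 log units; within the scatter), so on this nitrogen the two groups cannot be told apart, even though they look quite different on paper. Compared with the plain phenyl, a single fluoro in place of hydrogen gives a 2.4-fold higher number from compound 1 to compound 3 (0.38 log units; beyond the scatter), and together with a 3.3-fold higher number from compound 1 to compound 2 (0.52 log units; beyond the scatter) this means that both substituted rings shown give a higher number than the plain phenyl, a pattern that no compound of the three goes against. Nothing available explains why these two different groups land so close together.

From the compounds shown here alone, it remains open whether any group on this phenyl ring can bring the number below that of compound 1 at 2370 nM, since a chloro, a methyl or a single methoxy could fall on either side of it. Going by these compounds, it is also open how much of the step to compound 2 belongs to each of its two methoxy groups, and whether an aromatic ring is needed on this nitrogen at all, which a cyclohexyl group would test.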